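Acetyl removal from compound 1: working notes

The source may report more compounds than this note shows. Statements on the series, on what has been measured and on what is new or still open speak of the compounds shown alone.

- compound 1 `COc1cc(/C=C/c2cn(C(C)=O)c3ccccc23)cc(OC)c1OC`: > 5000 nM, a limit
- compound 2 `COc1cc(/C=C\c2cn(C(C)=O)c3ccccc23)cc(OC)c1OC`: 2850 nM

In a functional assay on HT-29 cells (Homo sapiens) for inhibition (a lower number here means a stronger inhibitor, a higher number a weaker inhibitor), compound 1 stands at > 5000 nM, which is a limit and not a number. The next compound is compound 3 `COc1cc(/C=C/c2c[nH]c3ccccc23)cc(OC)c1OC`, with hydrogen in place of acetyl on an aromatic nitrogen. For the measured compounds named here, the only measured step, an at least 1.7-fold lower number from compound 1 to compound 2 (0.24 log units; that floor lies within the scatter), rests on the fact that compounds 1 and 2 differ only in the configuration as drawn and leaves the acetyl in place, so it sets no size for this change. No step beyond the scatter is therefore expected in this assay, and no direction is favoured. The estimated step is an at least 1.2-fold lower number from compound 1 to compound 3 (0.09 log units; that floor lies within the scatter). For compound 3 the expected value is 4000 nM, with an estimated range of 800 nM to 20000 nM.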

Compound 3, half-maximal inhibitory concentration: 3230 nM
Beside the measured number, compound 3's estimate is 1.2-fold (0.09 log units) above it, within the range that was stated.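

Hydrogen in place of acetyl on an aromatic nitrogen gives an at least 1.5-fold lower number from compound 1 to compound 3 (0.18 log units; that floor lies within the scatter) in this assay and replaces a limit with a measured number. Acetyl on this nitrogen is therefore not needed for a measured number with the double bond drawn E. The size of the step stays open, as it rests on the limit of compound 1: the limit of > 5000 nM in this assay, at which 1 of the 3 values shown sits.

The compounds shown leave open how methyl or a longer acyl chain on this nitrogen would read. Also open, as far as these compounds go, is whether hydrogen in place of acetyl would read alike in compound 2, with its double bond drawn Z.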